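Allyl in place of hydroxymethyl on the acetophenone series

The source may report more compounds than this note shows. Statements on the series, on what has been measured and on what is new or still open speak of the compounds shown alone.

The two measured compounds share a core carrying an acetyl group, a phenol, and a nitrile-terminated ether chain. Compound 1 `CC(=O)c1cc(C)c(OCCCCC#N)cc1O` gives 35% in an assay on isolated protein for binding affinity to leukotriene B4 receptor 1 (Homo sapiens), tested at 1 uM; on this read-out lower numbers stand for less inhibition and higher numbers for more inhibition at the one concentration tested (going by the name of the read-out). Compound 2 `CC(=O)c1cc(CO)c(OCCCCCCC#N)cc1O` gives 8% in this assay, the lower of the two numbers, with compound 1 standing higher by a margin beyond the scatter. For the measured compounds named here, no single-point step links these two, as they differ in both the chain length and the group on the ring.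

Compound 3 `C=CCc1cc(C(C)=O)c(O)cc1OCCCCCCC#N` is not yet measured. It differs from compound 2 by vinyl in place of hydroxy on a saturated chain carbon bound to an aromatic carbon, which removes the only donor outside the phenol. Given that compound 1 gives 35% without a hydroxy on that chain carbon, the step of a number 14 percentage points higher from compound 2 to compound 3 (beyond the scatter) is expected to be a moderate rise in inhibition. Compound 3 is therefore estimated at 22%, within a range of 5% to 45%.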

Compound 3, a percentage reported as inhibition, at one concentration (the size of the read-out at that concentration, not a potency): 63%
Compound 3: middle estimate off by 41 percentage points, on the low side; measured number outside the range, above it.
By their numbers in this assay, from the lowest: compound 2; then compound 1; then compound 3.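

In this assay, for the compounds shown here, with the nitrile-terminated ether chain held the same, vinyl in place of hydroxy on a saturated chain carbon bound to an aromatic carbon gives a number 55 percentage points higher from compound 2 to compound 3 (beyond the scatter), the first comparison in this set that differs in one place only, and it shows that the group at this position strongly affects inhibition at the one concentration tested. By the computed counts, the change removes a hydrogen-bond donor and a hydrogen-bond acceptor and adds a double bond outside aromatic rings, but this single step cannot separate those differences. Nothing available here explains the rise.

From the compounds shown here alone, it remains open whether the double bond is needed, which a propyl group in place of allyl would address. The separate contribution of chain length also remains open, as no pair shown changes the chain alone.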